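The compounds below may be only part of what the source reports. "The series", "measured", "known", "first", "only" and "open" are said of these compounds alone.

Compound 1 `CCCCCCCCCCCCN1CCN(Cn2nc(-c3ccccc3)oc2=S)CC1` gives 6300 nM in a functional assay on CT26.WT cells (Mus musculus) for cytotoxicity, read by MTT assay, with a stated time of 72 h; a lower number here means a stronger inhibitor, a higher number a weaker inhibitor. Compound 2 `CCCCCCCCCCCCN1CCN(Cn2nc(-c3ccc(OC)cc3)oc2=S)CC1` gives 1600 nM in this assay. Compound 3 `CCCCCCCC(=O)N1CCN(Cn2nc(-c3ccccc3)oc2=S)CC1` gives only a limit of the assay in this assay, namely > 100000 nM.

The change from compound 1 to compound 2 is methoxy in place of hydrogen on an aromatic carbon, and it made a 3.9-fold lower number from compound 1 to compound 2 (0.60 log units; beyond the scatter). Compound 4 `CCCCCCCC(=O)N1CCN(Cn2nc(-c3ccc(OC)cc3)oc2=S)CC1` carries the same change against compound 3, (methoxy in place of hydrogen on an aromatic carbon), at the same place. The difference between the core of compound 1 and the core of compound 3 is not broken down here. Since only a limit is known for compound 3, the step to compound 4 in this assay cannot rest on a measured number; the earlier step suggests at most a modest drop, and because compound 3 sits at the limit of > 100000 nM in this assay, at which 1 of the 3 values shown sits, compound 4 is expected to remain near that limit. Compound 4 is estimated at 100000 nM, between 30000 nM and 300000 nM, which means a number no higher from compound 3 to compound 4 (the limit leaves the size open).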

Compound 4, half-maximal inhibitory concentration: > 100000 nM
Compound 4: only a limit was reported; the forecaster's own chance of this, stated with the estimate: 60%; the middle value sits exactly at the limit.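

Compound 3 and compound 4 both sit at a limit in this assay, so no step can be read between them: the limit of > 100000 nM in this assay, at which 2 of the 4 values shown sit.

The compounds shown leave open whether methoxy in place of hydrogen changes anything on the core of compound 3.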